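This account rests on a few compounds, and the source may have more. Where it says the series, first, only, none or still open, it means among the compounds named here.

compound 1 `O=C(/C=C/c1ccc(Cl)cc1)Nc1nc2ccccc2s1` – 367 umol/kg
compound 2 `O=C(/C=C/c1ccc(Cl)cc1)Nc1nc2ccc(Cl)cc2s1` – 204 umol/kg

In a functional assay on the whole organism (Hindlimb, strain albino) with Mus musculus as the target, in the maximal electroshock model, with a stated time of 0.5 h (a lower number here means that less compound is needed, a higher number that more compound is needed for the effect), compound 1 stands at 367 umol/kg and compound 2 at 204 umol/kg and the two lie within the scatter of each other. Compound 3 `O=C(/C=C/c1ccc(O)cc1)Nc1nc2ccccc2s1` has not yet been measured. Its difference from compound 1 is hydroxy in place of chloro on an aromatic carbon and amounts to hydroxy in place of chloro on an aromatic carbon, para to a large group, that is, 4-chlorophenyl to 4-hydroxyphenyl. Among the compounds with values here, the one measured step is a 1.8-fold lower number from compound 1 to compound 2 (0.26 log units; within the scatter) with chloro in place of hydrogen at a different place in the molecule, so it bears only loosely on this change. Within the data shown here, no measured step replaces the chloro of compound 1 itself. Going by these compounds, no step beyond the scatter is therefore expected in this assay and the direction stays open. The estimate means a 1.1-fold higher number from compound 1 to compound 3 (0.04 log units; within the scatter) and so an expected step within the scatter. Expected for compound 3 is 400 umol/kg with 150 umol/kg and 1000 umol/kg as the estimated ends of its range.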

Compound 3, dose for half-maximal effect: 517 umol/kg
Beside the measured number, compound 3's estimate is 1.3-fold (0.11 log units) below it; low and high end bracket the measured number.
By their numbers in this assay, from the lowest: compounds 2, 1 and 3 (each within the scatter of the next, the first and the last beyond it).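

In this assay, within the data shown here, the position para to a large group was probed directly for the first time, and hydroxy in place of chloro on this aromatic carbon gives a 1.4-fold higher number from compound 1 to compound 3 (0.15 log units; within the scatter) without leaving the scatter. The earlier step concerned chloro in place of hydrogen elsewhere in the molecule, whereas this one shows that 4-chlorophenyl and 4-hydroxyphenyl are not separated here, even though the change adds a hydrogen-bond donor and a hydrogen-bond acceptor. No measured finding accounts for this result.

The compounds shown leave open whether another group at this place, such as an amine, a methoxy group or a carboxylic acid, would move the number beyond the scatter. They also leave open whether 4-hydroxyphenyl would behave the same way on the chlorinated core of compound 2.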